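Series notes: N-methyl to N-ethyl lactam switch

The compounds below may be only part of what the source reports. "The series", "measured", "known", "first", "only" and "open" are said of these compounds alone.

Measured in a functional assay on HCT-116 cells (Homo sapiens) for inhibition, read by MTT assay, with a stated time of 48 h; on this read-out lower numbers stand for stronger inhibition and higher numbers for weaker inhibition:
compound 1 `COc1ccc(Nc2ncc3c(n2)N(C2CCCC2)CC(=O)N3C)cc1` gives 12300 nM
compound 2 `CCN1C(=O)CN(C2CCCC2)c2nc(Nc3ccc(OC)cc3)ncc21` gives 11000 nM
compound 3 `CN1CCN(c2ccc(Nc3ncc4c(n3)N(C3CCCC3)CC(=O)N4C)nc2)CC1` gives 9730 nM

Compound 1 and compound 2 share one core; compound 3 carries a different core, and the difference between the two cores is not broken down here. The change from compound 1 to compound 2 is methyl in place of hydrogen on a saturated chain carbon bound to an amide-type nitrogen in a ring and gave a 1.1-fold lower number from compound 1 to compound 2 (0.05 log units; within the scatter).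

Compound 4 `CCN1C(=O)CN(C2CCCC2)c2nc(Nc3ccc(N4CCN(C)CC4)cn3)ncc21` is not yet measured. It differs from compound 3 by methyl in place of hydrogen on a saturated chain carbon bound to an amide-type nitrogen in a ring, the same change seen from compound 1 to compound 2. The expected step is a 1.1-fold lower number from compound 3 to compound 4 (0.04 log units; within the scatter), resting on the step from compound 1 to compound 2 alone. Compound 4 is estimated at 8800 nM, with a range from 4000 nM to 19000 nM, the core change leaving the transfer uncertain.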

Compound 4, half-maximal inhibitory concentration: 16400 nM
Compound 4: the middle estimate sits 1.9-fold (0.27 log units) below what was measured, within the range that was stated.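

In this assay, methyl in place of hydrogen on a saturated chain carbon bound to an amide-type nitrogen in a ring gives a 1.7-fold higher number from compound 3 to compound 4 (0.23 log units; within the scatter). Set beside the earlier step, the change reads alike on the two cores as far as this read-out can tell: the same change on two cores in this assay, a 1.1-fold lower number (0.05 log units; within the scatter) from compound 1 to compound 2 and a 1.7-fold higher number (0.23 log units; within the scatter) from compound 3 to compound 4, 1.9-fold (0.28 log units) apart, within the scatter of two such steps. Going by these compounds alone, this shows no core dependence that can be told from scatter, but it does not show that the change has any effect or that it would carry to further cores, and only two pairs stand here, neither with a step beyond the scatter.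

Open, going by these compounds, is whether a longer chain such as propyl at this place would shift the number beyond the scatter. Also open, on these data alone, is what a chain ending in an amine or a carboxylic acid would do there.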